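A few compounds are considered here, and "the series" means these few. Any claim that something is new, unique, unknown or untested is made for them only; others in the source may bear on it.

Measured compounds in this assay:

Compound 1 `O=[N+]([O-])c1ccc(CN2CCC(n3cc(CC(OCc4cc(-c5ccccc5)no4)c4ccc(Br)cc4)nn3)CC2)cc1`: in a functional assay on MCF7 cells (Homo sapiens) for cytotoxicity, with a stated time of 48 h (on this read-out lower numbers stand for stronger inhibition and higher numbers for weaker inhibition), compound 1 gives only a limit, > 25000 nM.
Compound 2 `O=[N+]([O-])c1ccc(CN2CCC(n3cc(CC(OCc4cc(-c5ccc(Br)cc5)no4)c4ccc(Br)cc4)nn3)CC2)cc1`: compound 2 gives 4000 nM.
Compound 3 `COc1ccc(-c2cc(COC(Cc3cn(C4CCN(Cc5ccc([N+](=O)[O-])cc5)CC4)nn3)c3ccc(Br)cc3)on2)cc1`: compound 3 gives 4000 nM.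

Compound 2 stands level with compound 3, no change at the digits printed from compound 2 to compound 3 (within the scatter); the value of compound 1 is a limit of the assay (the limit of > 25000 nM in this assay, at which 1 of the 3 values shown sits). Against that limit the steps of an at least 6.2-fold lower number from compound 1 to compound 2 (0.79 log units; beyond the scatter) and an at least 6.2-fold lower number from compound 1 to compound 3 (0.79 log units; beyond the scatter) both read as at least modest gains, so a substituent on the phenyl ring attached to the five-membered ring carries the measurable potency seen so far, and the two substituents tried there cannot be told apart.

Compound 4 `O=[N+]([O-])c1ccc(CN2CCC(n3cc(CC(OCc4cc(-c5cccc(F)c5)no4)c4ccc(Br)cc4)nn3)CC2)cc1` differs from compound 2 in one place: 3-fluorophenyl in place of 4-bromophenyl on an aromatic carbon. The halogen is kept but moves on the ring and shrinks to fluorine. Within the data shown here, no measured step tests this position; the bearing steps are the loss of bromo between compound 2 and compound 1, and the swap to methoxy in compound 3. Compound 4 is therefore expected to sit between compound 2 and the limit of compound 1, a modest weakening, a 2.3-fold higher number from compound 2 to compound 4 (0.35 log units; beyond the scatter). The estimate for compound 4 in this assay is 9000 nM, with a range from 2500 nM to 30000 nM.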

Compound 4, half-maximal inhibitory concentration: 8000 nM
Beside the measured number, compound 4's estimate is 1.1-fold (0.05 log units) above it; the range from low to high includes it.
By their numbers in this assay, from the lowest: compounds 2, 3 and 4 (each within the scatter of the next). At a limit, above all of these: compound 1.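

In this assay, the 3-fluorophenyl group at this position cannot be separated from either earlier substituted phenyl ring, with a 2.0-fold higher number from compound 2 to compound 4 (0.30 log units; within the scatter) and a 2.0-fold higher number from compound 3 to compound 4 (0.30 log units; within the scatter), so a change of substituent together with a shift of its place on the ring leaves no readable difference here. The gain over the unsubstituted phenyl ring also appears with fluoro, an at least 3.1-fold lower number from compound 1 to compound 4 (0.49 log units; beyond the scatter), so among the compounds shown it is no longer tied to bromo or methoxy alone, and all three substituted compounds go with it. Compound 1 gives only a limit, so the size of this gain remains a lower bound: the limit of > 25000 nM in this assay, at which 1 of the 4 values shown sits.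

The compounds shown do not separate the kind of substituent from its place on the phenyl ring, as no single substituent appears at two places on that ring. They also leave open whether an amine, a carboxylic acid or a nitrile on that ring, or a cyclohexyl ring in place of the phenyl ring, would stay level with compound 2 at 4000 nM.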